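The source may report more compounds than this note shows. Statements on the series, on what has been measured and on what is new or still open speak of the compounds shown alone.

In a functional assay on L1210 cells (Mus musculus) for antiproliferative activity, read by cell counting, with a stated time of 48 h (a lower number here means a stronger inhibitor, a higher number a weaker inhibitor), compound 1 `C#C[C@@]1(O)[C@@H](CO)O[C@@H](n2cnc3c(-c4ccccc4)ncnc32)[C@@H]1O` reads > 250000 nM, which is a limit of the assay and not a number. Compound 2 `C#C[C@@]1(O)[C@@H](CO)O[C@@H](n2cnc3c(-c4ccc(Cl)cc4)ncnc32)[C@@H]1O` gives 225000 nM. Within the data shown here, compound 3 `C#C[C@@]1(O)[C@@H](CO)O[C@@H](n2cc(Br)c3c(N)ncnc32)[C@@H]1O`, on a different core, gives 28 nM, the lowest number so far and far from its nearest neighbour, compound 2.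

The next change, to compound 4 `C#C[C@@]1(O)[C@@H](CO)O[C@@H](n2cc(C(F)(F)F)c3c(N)ncnc32)[C@@H]1O`, is trifluoromethyl in place of bromo on an aromatic carbon of the five-membered aromatic ring. Among the measured compounds shown here, the only measured step, an at least 1.1-fold lower number from compound 1 to compound 2 (0.04 log units; that floor lies within the scatter), rests on the limit of > 250000 nM in this assay, at which 1 of the 3 values shown sits, and sits on the other core, so it gives no measure for this change. For the measured compounds named here, no step at this place has been measured.

The expectation is therefore anchored on compound 3 at 28 nM alone. In this assay a modest move to a higher number is expected, though a step within the scatter remains possible. The expected move is a 2.9-fold higher number from compound 3 to compound 4 (0.46 log units; beyond the scatter). For compound 4 the estimated value is 80 nM, with an expected range of 15 nM to 600 nM.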

Compound 4, half-maximal inhibitory concentration: 110 nM
Compound 4: middle estimate off by 1.4-fold (0.14 log units), on the low side; measured number inside the range.
By their numbers in this assay, from the lowest: compound 3; then compound 4; then compound 2. At a limit, above all of these: compound 1.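

In this assay this position now has its first measured step, with trifluoromethyl in place of bromo: a 3.9-fold higher number from compound 3 to compound 4 (0.59 log units; beyond the scatter). Bromo is thus not the only group on this carbon of the five-membered aromatic ring that gives a low number: compound 4 reads 110 nM with 4 heavy atoms in the group instead of 1, although the step is modest, lies beyond the scatter and favours bromo. Nothing shown here gives a measured property of either group that could account for this step.

Going by these compounds, whether an amine, a carboxylic acid, a nitrile or a longer chain on this carbon would read nearer to compound 3 or further from it remains open. With only compound 3 and compound 4 compared at this position, no trend across groups can be drawn.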